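Ester variation on the side chain: tolerated concentration

The source may report more compounds than this note shows. Statements on the series, on what has been measured and on what is new or still open speak of the compounds shown alone.

Compound 1 `O=c1c(CCO)c(-c2ccccc2Cl)c2cc(Cl)ccc2n1-c1c(F)cccc1F` carries a free alcohol on the shared core. In an ADME assay on HepG2 2.2.15 cells (Homo sapiens) for cytotoxicity (a higher number here means that more compound is tolerated, a lower number that less compound is tolerated), compound 1 reaches only the limit of the measurement, > 2300000 nM, and no number. Compound 2 `O=C(OCCc1c(-c2ccccc2Cl)c2cc(Cl)ccc2[nH]c1=O)C1CCCC1` converts that alcohol into a cyclopentyl ester; in this assay compound 2 gives 46000 nM. For the measured compounds named here, this is the only real number available so far; the other entry is a limit, as noted for compound 1 (the limit of > 2300000 nM in this assay, at which 1 of the 2 values shown sits), so no measured step between compounds exists and nothing can be said about the size of the change from the free alcohol to the ester.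

Compound 3 `COc1cccc(/C=C/C(=O)OCCc2c(-c3ccccc3Cl)c3cc(Cl)ccc3[nH]c2=O)c1` is the next ester: 2-(3-methoxyphenyl)ethenyl in place of cyclopentyl on a carbonyl carbon, on a carbonyl carbon whose other neighbours are an oxygen next to a carbonyl group. Going by the values given here, with no measured step to lean on, the expected step from compound 2 to compound 3 in this assay is small, a 1.5-fold lower number from compound 2 to compound 3 (0.19 log units; within the scatter), within the usual scatter. Compound 3 is therefore estimated at 30000 nM in this assay, with a range from 8000 nM to 120000 nM.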

Compound 3, half-maximal cytotoxic concentration: > 1300000 nM
Compound 3 was reported as a limit; the forecaster's own chance of this, stated with the estimate: 10%; middle value at least 43-fold (1.63 log units) away from the limit.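

Working note on the group on the carbonyl carbon: in this assay, 2-(3-methoxyphenyl)ethenyl in place of cyclopentyl gives an at least 28-fold higher number from compound 2 to compound 3 (1.45 log units; beyond the scatter), the first step in the series that can be read and one that lies beyond the scatter. Compound 2 and compound 3 share the ester on the side chain and differ only in this group, so the ester link alone does not set the tolerated concentration, and the group on the carbonyl carbon can shift it strongly. Compound 3 gives a limit and not a number, so the step has a lower bound but no upper one: the limit of > 1300000 nM in this assay, at which 1 of the 3 values shown sits.

On these data alone, the entering group brings an aromatic ring, a double bond and a methoxy group together, so it remains open which of these parts goes with the change, and a simple phenyl or 2-phenylethenyl group on the carbonyl carbon would separate them. As far as these compounds go, it also remains open how the tolerated concentration responds to a small acetyl group, or to an amine or carboxylic acid carried on the group at this position.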